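The source may report more compounds than this note shows. Statements on the series, on what has been measured and on what is new or still open speak of the compounds shown alone.

Compound 1 `CN(C)CCNc1nc(-c2ccc(NC(=O)Nc3ccc(Cl)cc3)cc2)nc2ccsc12`: 130 nM in a functional assay on NCI-H460 cells (Homo sapiens) for cytotoxicity, read by MTT assay, with a stated time of 72 h; on this read-out higher numbers stand for weaker inhibition and lower numbers for stronger inhibition
Compound 2 `CCN(CC)CCCNc1nc(-c2ccc(NC(=O)Nc3ccc(Cl)cc3)cc2)nc2ccsc12`: 81 nM
Compound 3 `CCN(CC)CCCNc1nc(-c2ccc(NC(=O)Nc3ccccc3Cl)cc2)nc2ccsc12`: 200 nM

Compound 2 shows the lowest number of the three in this assay. Its nearest neighbour is compound 1, with a 1.6-fold lower number from compound 1 to compound 2 (0.21 log units; within the scatter), and its furthest is compound 3, with a 2.5-fold higher number from compound 2 to compound 3 (0.39 log units; beyond the scatter). Compound 4 `CCN(CC)CCNc1nc(-c2ccc(NC(=O)Nc3ccc(Cl)cc3)cc2)nc2ccsc12` differs from compound 2 by diethylamino in place of (diethylamino)methyl on a saturated chain carbon, two bonds along the chain from a nitrogen on an aromatic ring. Within the data shown here, only one measured step bears on this part of the molecule, a 1.6-fold lower number from compound 1 to compound 2 (0.21 log units; within the scatter), which altered both the chain length and the amine and still stayed within the scatter. No step beyond the scatter is therefore expected in this assay. Compound 4 is estimated at 100 nM, with a range from 50 nM to 200 nM. The expected step is a 1.2-fold higher number from compound 2 to compound 4 (0.09 log units; within the scatter).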

Compound 4, half-maximal inhibitory concentration: 190 nM
For compound 4 the middle estimate is 1.9-fold (0.28 log units) below the measured one; the range from low to high includes it.
By their numbers in this assay, from the lowest: compounds 2, 1, 4 and 3 (each within the scatter of the next, the first and the last beyond it).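

In this assay, shortening 3-(diethylamino)propyl to 2-(diethylamino)ethyl with the amine held fixed gives a 2.3-fold higher number from compound 2 to compound 4 (0.37 log units; beyond the scatter), so chain length at this position registers as a modest step on its own, which the earlier change of chain and amine together could not show. With the chain held instead, diethylamino in place of dimethylamino gives a 1.5-fold higher number from compound 1 to compound 4 (0.16 log units; within the scatter), so this amine change stays within the scatter. No measurement here accounts for either step.

The compounds shown leave open how 3-(dimethylamino)propyl would compare, and whether a longer chain or a piperidine or morpholine at the chain end would keep these numbers.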